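Swapping a Pyridine for a Fluorophenyl on the Side Chain

The source may hold more compounds than are shown below. What is called first, only, known or untested is meant among the compounds shown, and "the series" means these compounds.

Measured compounds:
- compound 1, `O[C@@H](c1ccccc1)[C@H]1CO[C@H](c2ccccc2)[C@@H](C/C=C/c2ccccn2)C1`, gives 33800 nM
- compound 2, `COc1cccc(/C=C/C[C@@H]2C[C@@H]([C@@H](O)c3ccc(OC)c(OC)c3)CO[C@H]2c2ccc(OC)c(OC)c2)c1`, gives 16400 nM

Of the compounds shown here, two have been tested in a functional assay on HeLa cells (Homo sapiens) for cytotoxicity, read by WST assay, with a stated time of 48 h; on this read-out higher numbers stand for weaker inhibition and lower numbers for stronger inhibition. Compound 1 stands at the highest of the two numbers; its nearest neighbour is compound 2, whose number is lower by a gap that lies beyond the usual scatter of repeated measurements. For the measured compounds named here, compound 2 differs from compound 1 in several places at once, so no single step between them can be read from their two values.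

Compound 3, `O[C@@H](c1ccccc1)[C@H]1CO[C@H](c2ccccc2)[C@@H](C/C=C/c2ccccc2F)C1`, has not yet been measured in this assay. It differs from compound 1 in one place: 2-fluorophenyl in place of pyridin-2-yl on a double-bonded chain carbon bound to a double-bonded chain carbon. Going by the values given here, no measured pair shows the effect of this change, so the expectation can rest only on the value of compound 1. A step of no more than the scatter is expected from compound 1 to compound 3 in this assay, in either direction, with the estimate being a 1.2-fold lower number from compound 1 to compound 3 (0.08 log units; within the scatter). Compound 3 is accordingly expected to give about 28000 nM, within a range of 9000 nM to 85000 nM.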

Compound 3, half-maximal inhibitory concentration: 9730 nM
For compound 3 the middle estimate is 2.9-fold (0.46 log units) above the measured one; measured number inside the range.
By their numbers in this assay, from the lowest: compounds 3 and 2 (each within the scatter of the next); then compound 1.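

In this assay, the group at the end of the side chain matters: 2-fluorophenyl in place of pyridin-2-yl on a double-bonded chain carbon bound to a double-bonded chain carbon gives a 3.5-fold lower number from compound 1 to compound 3 (0.54 log units; beyond the scatter), and this is the only single-place step among the compounds shown. The change removes the ring nitrogen, with the one hydrogen-bond acceptor counted for pyridin-2-yl, and brings in a fluorine, so these two differences arrive together and the step cannot be assigned to either one alone. No measurement at hand accounts for the step, so it stands as an observed difference without an explanation.

The compounds shown leave open what a plain phenyl would give at this place, which would separate the loss of the ring nitrogen from the gain of the fluorine, and whether a 2-chlorophenyl or a 2-methoxyphenyl would behave like 2-fluorophenyl. They also leave open whether the same swap would carry the same weight on a core bearing the methoxy groups of compound 2.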